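The source may hold more compounds than are shown below. What is called first, only, known or untested is meant among the compounds shown, and "the series" means these compounds.

Measured compounds:
compound 1, `Cc1cc2c(cc1C(=O)N=C(N)N)S(=O)(=O)CC2(C)O`, 115 nM
compound 2, `COC1(C)CS(=O)(=O)c2cc(C(=O)N=C(N)N)c(C)cc21`, 321 nM
compound 3, `Cc1cc2c(cc1C(=O)N=C(N)N)S(=O)(=O)C(C)(C)C2O`, 258 nM

In a functional assay for inhibition, with Homo sapiens as the target (on this read-out lower numbers stand for stronger inhibition and higher numbers for weaker inhibition), compound 1 gives 115 nM. Compound 2 differs from it by methyl in place of hydrogen on an oxygen on a saturated carbon, and this change produced a 2.8-fold higher number from compound 1 to compound 2 (0.45 log units; beyond the scatter). Among the compounds with values here, compound 3 differs from compound 1 in more than one place, so no single step between them is counted. In this assay compound 3 gives 258 nM, so that compound 3 and compound 2 sit within the scatter of each other, while compound 3 sits beyond the scatter from compound 1.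

Compound 4, `COC1c2cc(C)c(C(=O)N=C(N)N)cc2S(=O)(=O)C1(C)C`, has not yet been measured. Within the data shown here, it differs from compound 3 by methyl in place of hydrogen on an oxygen on a saturated carbon, and this is the same change as the one from compound 1 to compound 2: the groups that leave and enter are the same, and the place is described in the same words, on an oxygen on a saturated carbon whose other neighbours are a saturated ring carbon. Among the measured compounds shown here, the one earlier instance of this change gave a 2.8-fold higher number from compound 1 to compound 2 (0.45 log units; beyond the scatter). The core of compound 3 is not the core of compound 1, and the step is expected to be of the same kind rather than identical. The estimated step is a 2.4-fold higher number from compound 3 to compound 4 (0.38 log units; beyond the scatter) in this assay. On that basis compound 4 is expected to give 620 nM in this assay, with a range from 300 nM to 1300 nM.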

Compound 4, half-maximal inhibitory concentration: 138 nM
Compound 4: the middle estimate sits 4.5-fold (0.65 log units) above what was measured; the whole stated range lies above it.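

On the core of compound 3, the change from hydroxy to methoxy gave a 1.9-fold lower number from compound 3 to compound 4 (0.27 log units; within the scatter) in this assay, so on this read-out the two compounds cannot be told apart. Set beside the earlier instance, the same change does not behave as one fixed step that can be carried from one core to the other: the same change on two cores in this assay, a 2.8-fold higher number (0.45 log units; beyond the scatter) from compound 1 to compound 2 and a 1.9-fold lower number (0.27 log units; within the scatter) from compound 3 to compound 4, 5.2-fold (0.72 log units) apart, beyond the scatter of two such steps. This shows that, for these two cores, the size of the step depends on the core that carries it, so a step read on one core is a poor guide to the other; it does not show which feature of the cores is responsible, as compound 1 and compound 3 differ in more than one place, and two instances give no rule for any further core.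

The compounds shown leave open what a longer chain such as ethoxy on that oxygen, or an amine in place of the hydroxy, would do on either core. They also leave open which way the hydroxy to methoxy step would go on a core that carries only one of the differences between compound 1 and compound 3.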